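The compounds below may be only part of what the source reports. "The series", "measured", "known", "first", "only" and "open" are said of these compounds alone.

In a functional assay on HT-29 cells (Homo sapiens) for inhibition, read by MTT assay, with a stated time of 48 h (a higher number here means a weaker inhibitor, a lower number a stronger inhibitor), only one of the three tested compounds returned an actual number: compound 3 (`COc1cc(-c2nnc(SCC(=O)c3ccccc3)n2-c2ccc(N(C)C)cc2)cc(OC)c1OC`) gives 45200 nM there. Compound 2 (`COc1cc(-c2nnc(S)n2-c2ccc(N(C)C)cc2)cc(OC)c1OC`), with hydrogen on its sulfur, reads > 60000 nM as a limit of the assay, not a number. Compound 1 (`COc1ccc(-n2c(SCC(=O)C3CC3)nnc2-c2cc(OC)c(OC)c(OC)c2)cc1`), which carries (cyclopropylcarbonyl)methyl on its sulfur, reads > 60000 nM as a limit too. Both sit at the same mark (the limit of > 60000 nM in this assay, at which 2 of the 3 values shown sit), so compound 3 has no second number to be ranked against.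

Compound 4 (`COc1cc(-c2nnc(SCC(=O)C3CC3)n2-c2ccc(N(C)C)cc2)cc(OC)c1OC`) keeps the rest of compound 3 and changes one group: cyclopropyl in place of phenyl on a carbonyl carbon. Among the measured compounds shown here, only one measured step bears on this change, the arrival of benzoylmethyl in place of hydrogen on a sulfur (an at least 1.3-fold lower number from compound 2 to compound 3 (0.12 log units; that floor lies within the scatter)), and its floor lies within the scatter. That step sets no firm size for the new change. No step beyond the scatter is therefore expected in this assay for this swap, with a slight lean towards a higher number, and a result reported only as a limit is quite possible. The estimate amounts to an expected change of a 1.2-fold higher number from compound 3 to compound 4 (0.09 log units; within the scatter) in all. Compound 4 is thus expected to give 55000 nM (estimated range from 20000 nM to 100000 nM).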

Compound 4, half-maximal inhibitory concentration: > 60000 nM
Compound 4: only a limit was reported (the forecaster's own chance of this, stated with the estimate: 55%); middle value at least 1.0-fold (0.03 log units) from the limit.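

Replacing the phenyl on the carbonyl carbon with cyclopropyl, which has 3 heavy atoms where phenyl has 6, gives an at least 1.3-fold higher number from compound 3 to compound 4 (0.12 log units; that floor lies within the scatter) in this assay. Because that floor lies within the scatter, the step does not establish that phenyl is needed here, only that cyclopropyl in this place does not give a measurable number in this set. The steps to compound 4 from compound 2 and from compound 1 cannot be read, as both ends of each are limits, and compound 3 remains the only compound with an actual number: the limit of > 60000 nM in this assay, at which 3 of the 4 values shown sit.

The compounds shown cover only phenyl and cyclopropyl on this carbonyl carbon, so they leave open whether a pyridine ring, a tert-butyl group or a longer chain there would give a number, and how large it would be. With a single number in the set, they also leave open how much of the reading of compound 3 comes from the phenyl and how much from the dimethylamino group.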